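The compounds below may be only part of what the source reports. "The series", "measured", "known", "first", "only" and "open" are said of these compounds alone.

Of the compounds shown here, two have so far been measured in an assay for inhibition of 15-hydroxyprostaglandin dehydrogenase [NAD(+)] (Homo sapiens), read by fluorescence, with a stated time of 15 min, in the presence of a further agent that is not named here; on this read-out higher numbers stand for weaker inhibition and lower numbers for stronger inhibition. Compound 1 `CCCC[S+]([O-])c1sc2nc(-c3nccs3)cc(-c3ccc(COC(=O)CN(C)C)cc3)c2c1N` gives 3.5 nM there, the lowest of the two numbers, while compound 2 `CCC[S+]([O-])c1sc2nc(-c3cccs3)cc(C(=O)N(C)C)c2c1N` gives 14.7 nM, a higher number that lies beyond the usual scatter. Compound 3 `CCCC[S+]([O-])c1sc2nc(-c3nccs3)cc(-c3ccc(CN)cc3)c2c1N` has not yet been measured. It differs from compound 1 in a single place: amino in place of (((dimethylamino)methyl)carbonyl)oxy on a saturated chain carbon bound to an aromatic carbon. Among the measured compounds shown here, no measured pair carries this change, so the step of a 1.7-fold higher number from compound 1 to compound 3 (0.23 log units; within the scatter) is only an expectation, a slight shift toward a higher number within the scatter. For compound 3 the estimate is 6 nM, ranging from 2 nM to 20 nM.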

Compound 3, half-maximal inhibitory concentration: 11.5 nM
Estimate against measurement, compound 3: 1.9-fold (0.28 log units) below; measured number inside the range.
By their numbers in this assay, from the lowest: compound 1; then compounds 3 and 2 (each within the scatter of the next).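

In this assay, amino in place of (((dimethylamino)methyl)carbonyl)oxy on a saturated chain carbon bound to an aromatic carbon gives a 3.3-fold higher number from compound 1 to compound 3 (0.52 log units; beyond the scatter), a modest step. This shows that the group at this place affects the number, yet compound 3 with the far smaller amino still reads 11.5 nM. Nothing measured here accounts for the step.
From the compounds shown here alone, whether the step belongs to the ester or to its dimethylamino end stays open. A hydroxyl, a dimethylamino group or a carboxylic acid on the same carbon would bear on that.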